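A few compounds are considered here, and "the series" means these few. Any claim that something is new, unique, unknown or untested is made for them only; others in the source may bear on it.

Measured in a functional assay, read by spectrophotometry, with a stated time of 5 min; on this read-out lower numbers stand for stronger inhibition and higher numbers for weaker inhibition:
- compound 1 `COc1cc(/C=C/C(=O)C(=Cc2ccc(OC)c(OC)c2)C(=O)/C=C/c2ccc(O)c(OC)c2)ccc1O`: 71000000 nM
- compound 2 `CCOc1cc(C=C(C(=O)/C=C/c2ccc(O)c(OC)c2)C(=O)/C=C/c2ccc(O)c(OC)c2)ccc1O`: 123000000 nM
- compound 3 `COc1cc(/C=C/C(=O)C(=Cc2ccc(O)c(O)c2)C(=O)/C=C/c2ccc(O)c(OC)c2)ccc1O`: 10400000 nM

Compound 3, at 10400000 nM, has the lowest number of the three and is the strongest inhibitor among them. Compound 4 `COc1cc(/C=C/C(=O)C(=Cc2ccccc2)C(=O)/C=C/c2ccc(O)c(OC)c2)ccc1O` carries phenyl in place of 3,4-dihydroxyphenyl on a double-bonded chain carbon bound to a double-bonded chain carbon.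

Going by the values given here, two measured steps bear on this change: a 6.8-fold lower number from compound 1 to compound 3 (0.83 log units; beyond the scatter), and a 12-fold lower number from compound 2 to compound 3 (1.07 log units; beyond the scatter). Both end on the 3,4-dihydroxyphenyl group, and compound 4 gives that group up. Among the compounds with values here, no measured compound carries plain phenyl, so the size remains uncertain. A higher number is expected in this assay, with an estimated 7.7-fold higher number from compound 3 to compound 4 (0.89 log units; beyond the scatter). For compound 4 the expected value is 80000000 nM, with an estimated range from 25000000 nM to 250000000 nM.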

Compound 4, half-maximal inhibitory concentration: 84400000 nM
Beside the measured number, compound 4's estimate is 1.1-fold (0.02 log units) below it; measured number inside the range.
By their numbers in this assay, from the lowest: compound 3; then compounds 1, 4 and 2 (each within the scatter of the next).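

Swapping 3,4-dihydroxyphenyl for plain phenyl on this chain carbon weakens inhibition in this assay (an 8.1-fold higher number from compound 3 to compound 4 (0.91 log units; beyond the scatter)). Phenyl cannot be told apart from 3-ethoxy-4-hydroxyphenyl (a 1.5-fold lower number from compound 2 to compound 4 (0.16 log units; within the scatter)) or from 3,4-dimethoxyphenyl (a 1.2-fold higher number from compound 1 to compound 4 (0.08 log units; within the scatter)), so among these four compounds only 3,4-dihydroxyphenyl stands apart. Nothing available explains why this group differs from the others.

On these data alone, whether both hydroxy groups are needed, or a single one would do, stays open. So does whether an aminophenyl or a carboxyphenyl group at this place would match 3,4-dihydroxyphenyl.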